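Bromo removal on the trimethoxy enaminone series

The source may report more compounds than this note shows. Statements on the series, on what has been measured and on what is new or still open speak of the compounds shown alone.

Working notes. In a functional assay on MIA PaCa-2 cells (Homo sapiens) for antiproliferative activity, read by sulforhodamine B assay, with a stated time of 48 h (on this read-out higher numbers stand for weaker inhibition and lower numbers for stronger inhibition), compound 1 `COc1ccc2nc(-c3ccc(N/C=C\C(=O)c4cc(OC)c(OC)c([N+](=O)[O-])c4)cc3)sc2c1` gives 25600 nM. Compound 2 `COc1ccc2nc(-c3ccc(N/C=C\C(=O)c4cc(OC)c(OC)c(OC)c4)c(C)c3)sc2c1` gives 10000 nM in this assay. Compound 3 `COc1ccc2nc(-c3ccc(N/C=C\C(=O)c4cc(OC)c(OC)c(OC)c4Br)cc3)sc2c1` gives 14700 nM in this assay. Among these three numbers compound 3 stands second highest; its nearest neighbour is compound 2 and its furthest is compound 1, and both of those gaps lie within the scatter, so no order among the three compounds can be read from them.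

Compound 4 `COc1ccc2nc(-c3ccc(N/C=C\C(=O)c4cc(OC)c(OC)c(OC)c4)cc3)sc2c1` has not been measured in this assay. It differs from compound 3 by hydrogen in place of bromo on an aromatic carbon on an aromatic carbon of a six-membered aromatic ring of carbon only, ortho to a large group and ortho to a methoxy group. Going by the values given here, no pair of measured compounds isolates this change, so the expectation rests on compound 3 alone and on the fact that the three measured numbers sit close together. In this assay a modest step toward a lower number is expected, a 1.8-fold lower number from compound 3 to compound 4 (0.26 log units; within the scatter), perhaps only at the edge of the scatter. Compound 4 is estimated at 8000 nM, with a range from 3000 nM to 25000 nM.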

Compound 4, half-maximal inhibitory concentration: 31100 nM
Estimate against measurement, compound 4: 3.9-fold (0.59 log units) below; the measured number lies above the stated range.
By their numbers in this assay, from the lowest: compounds 2, 3, 1 and 4 (each within the scatter of the next, the first and the last beyond it).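

The bromo on the aromatic carbon ortho to a large group and ortho to a methoxy group does not cost activity in this assay: with hydrogen in its place there is a 2.1-fold higher number from compound 3 to compound 4 (0.33 log units; beyond the scatter), so the step runs toward weaker inhibition, and the unsubstituted trimethoxy compound is not a better parent for this position. The methyl step points the same way, with a 3.1-fold higher number from compound 2 to compound 4 (0.49 log units; beyond the scatter), so two separate substituents each go with stronger inhibition than hydrogen, though both steps are modest. Methoxy in place of nitro on an aromatic carbon goes against any general gain from changing a group, with a 1.2-fold higher number from compound 1 to compound 4 (0.08 log units; within the scatter) lying within the scatter, and no measurement shown here accounts for the bromo or methyl steps.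

Going by these compounds, each of these readings rests on a single pair, so it remains open whether chloro or fluoro at the bromo position would match bromo or whether size of the halogen matters at all. On these data alone, an amine or a carboxylic acid at that same carbon, and a bromo combined with the methyl of compound 2, also remain open.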